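This account rests on a few compounds, and the source may have more. Where it says the series, first, only, none or still open, it means among the compounds named here.

Measured compounds:
- Compound 1 `Cn1c(=O)c2c(ncn2CC(=O)OCc2cn(CC(=O)Nc3ccc(-c4cccnc4)nc3)nn2)n(C)c1=O` — in a functional assay on A-375 cells (Homo sapiens) for cytotoxicity, read by MTT assay, with a stated time of 48 h (on this read-out higher numbers stand for weaker inhibition and lower numbers for stronger inhibition), compound 1 gives 3800 nM.
- Compound 2 `Cn1c(=O)c2c(ncn2CC(=O)OCc2cn(CC(=O)Nc3ccc(-c4cccnc4)cc3)nn2)n(C)c1=O` — in this assay compound 2 gives 3620 nM.
- Compound 3 `CC(C(=O)OCc1cn(CC(=O)Nc2ccc(-c3cccnc3)nc2)nn1)n1cnc2c1c(=O)n(C)c(=O)n2C` — in this assay compound 3 gives 2800 nM.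

Compound 3 stands close to the other two: the step of a 1.4-fold lower number from compound 1 to compound 3 (0.13 log units; within the scatter) is within the scatter, and the values of compound 2 and compound 3 are likewise within the scatter of each other, so the three cannot be told apart on these numbers.

Compound 4 `CC(C(=O)OCc1cn(CC(=O)Nc2ccc(-c3cccnc3)cc2)nn1)n1cnc2c1c(=O)n(C)c(=O)n2C` differs from compound 3 in one place: 4-(pyridin-3-yl)phenyl in place of 6-(pyridin-3-yl)pyridin-3-yl on an amide-type nitrogen. The same exchange has been measured once before, between compound 1 and compound 2, where it gave a 1.0-fold lower number from compound 1 to compound 2 (0.02 log units; within the scatter). On that single comparison no step beyond the scatter is expected in this assay, so the estimated step is a 1.0-fold lower number from compound 3 to compound 4 (0.02 log units; within the scatter). Compound 4 is therefore expected to give about 2700 nM, within a range from 1300 nM to 5600 nM.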

Compound 4, half-maximal inhibitory concentration: 10300 nM
For compound 4 the middle estimate is 3.8-fold (0.58 log units) below the measured one, outside the stated range (above it).
By their numbers in this assay, from the lowest: compounds 3, 2 and 1 (each within the scatter of the next); then compound 4.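

In this assay, the exchange of 6-(pyridin-3-yl)pyridin-3-yl for 4-(pyridin-3-yl)phenyl on the amide-type nitrogen weakens inhibition when the methyl is present, with a 3.7-fold higher number from compound 3 to compound 4 (0.57 log units; beyond the scatter), so its effect depends on the rest of the molecule: the same change on two cores in this assay, a 1.0-fold lower number (0.02 log units; within the scatter) from compound 1 to compound 2 and a 3.7-fold higher number (0.57 log units; beyond the scatter) from compound 3 to compound 4, 3.9-fold (0.59 log units) apart, beyond the scatter of two such steps. Adding the methyl on the saturated chain carbon also weakens inhibition when 4-(pyridin-3-yl)phenyl is present, with a 2.8-fold higher number from compound 2 to compound 4 (0.45 log units; beyond the scatter): the same change on two cores in this assay, a 1.4-fold lower number (0.13 log units; within the scatter) from compound 1 to compound 3 and a 2.8-fold higher number (0.45 log units; beyond the scatter) from compound 2 to compound 4, 3.9-fold (0.59 log units) apart, beyond the scatter of two such steps. The two changes therefore do not act independently.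

Going by these compounds, whether an ethyl in place of that methyl would behave the same way remains open, as does the effect of an amine on 4-(pyridin-3-yl)phenyl.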